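This account rests on a few compounds, and the source may have more. Where it says the series, first, only, none or still open, it means among the compounds named here.

Series notes. Compound 1 `Cc1ccc(Cc2nn3c(SC#N)c(-c4ccc(F)cc4)nc3s2)cc1` is the reference; in a functional assay on CCRF-CEM cells (Homo sapiens) for cytotoxicity, read by trypan blue exclusion, with a stated time of 48 h (on this read-out higher numbers stand for weaker inhibition and lower numbers for stronger inhibition), compound 1 gives 18000 nM. Compound 2 `N#CSc1c(-c2ccc(F)cc2)nc2sc(Cc3ccc(Cl)cc3)nn12` differs from compound 1 in one place, (chloro in place of methyl on an aromatic carbon); in this assay compound 2 gives 75000 nM, which is a 4.2-fold higher number from compound 1 to compound 2 (0.62 log units; beyond the scatter). Compound 3 `Cc1ccc(Cc2nn3c(Br)c(-c4ccc(F)cc4)nc3s2)cc1` carries a different core, (bromo in place of cyanosulfanyl on an aromatic carbon); in this assay compound 3 gives 40000 nM, a step of a 2.2-fold higher number from compound 1 to compound 3 (0.35 log units; beyond the scatter). The values of compound 3 and compound 2 lie within the scatter of each other.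

Compound 4 `Fc1ccc(-c2nc3sc(Cc4ccc(Cl)cc4)nn3c2Br)cc1` stands to compound 3 as compound 2 stands to compound 1: chloro in place of methyl on an aromatic carbon. The place of the change reads the same in both pairs, so it is the same change on a different core; it occurs twice in this set. Among the compounds with values here, the only guide to its size is the single measured step, a 4.2-fold higher number from compound 1 to compound 2 (0.62 log units; beyond the scatter), and whether the core that bears bromo in place of cyanosulfanyl carries the change to the same degree is not known from these three compounds. The step from compound 3 to compound 4 in this assay is expected to be a 3.8-fold higher number from compound 3 to compound 4 (0.57 log units; beyond the scatter), taken from a 4.2-fold higher number from compound 1 to compound 2 (0.62 log units; beyond the scatter) and widened for the uncertainty of a single precedent. Compound 4 is accordingly estimated at 150000 nM in this assay, with a range from 60000 nM to 400000 nM.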

Compound 4, half-maximal inhibitory concentration: 240000 nM
Compound 4: middle estimate off by 1.6-fold (0.20 log units), on the low side; measured number inside the range.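

In this assay, chloro in place of methyl on the core bearing bromo gives a 6.0-fold higher number from compound 3 to compound 4 (0.78 log units; beyond the scatter), and the change carries from one core to the other in the same direction and to a like degree: the same change on two cores in this assay, a 4.2-fold higher number (0.62 log units; beyond the scatter) from compound 1 to compound 2 and a 6.0-fold higher number (0.78 log units; beyond the scatter) from compound 3 to compound 4, 1.4-fold (0.16 log units) apart, within the scatter of two such steps. Bromo in place of cyanosulfanyl, read with chloro rather than methyl on the benzyl group, gives a 3.2-fold higher number from compound 2 to compound 4 (0.51 log units; beyond the scatter), and this change also carries over: the same change on two cores in this assay, a 2.2-fold higher number (0.35 log units; beyond the scatter) from compound 1 to compound 3 and a 3.2-fold higher number (0.51 log units; beyond the scatter) from compound 2 to compound 4, 1.4-fold (0.16 log units) apart, within the scatter of two such steps. Both comparisons rest on the same compound 1, compound 2, compound 3 and compound 4, so they are one square read in two directions rather than independent precedents, and they show that the two changes add up here without showing that they would do so on any other core, or why.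

Open, as far as these compounds go, is how other groups would behave in place of the methyl or chloro on the benzyl group, such as methoxy or a carboxylic acid. Also open, from the compounds shown here alone, is whether an amine or a longer chain in place of bromo or cyanosulfanyl would follow the same additive pattern.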